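This account rests on a few compounds, and the source may have more. Where it says the series, first, only, none or still open, it means among the compounds named here.

Compound 1 `Nc1ccccc1NC(=O)CCCNCC(=O)Nc1ccc(Cl)cc1`: 72.7%
Compound 2 `Nc1ccccc1NC(=O)c1ccc(NCC(=O)Nc2ccc([N+](=O)[O-])cc2)cc1`: 83.3%
Compound 3 `Nc1ccccc1NC(=O)c1ccc(NCC(=O)Nc2cccc([N+](=O)[O-])c2)cc1`: 67.6%

In a functional assay on the whole organism (Ehrlich cells, Mus musculus) for antiproliferative activity, with a stated time of 24 h, at a dose of 0.2 mmol/kg by the intraperitoneal route (on this read-out higher numbers stand for more inhibition at the one dose given (going by the name of the read-out) and lower numbers for less inhibition), compound 1 gives 72.7%, the second highest of the three numbers: compound 3 sits within the scatter of it, while compound 2 lies beyond the scatter above it. Compound 4 `Nc1ccccc1NC(=O)CCCNCC(=O)Nc1cc(Cl)ccc1Cl` differs from compound 1 in one place: 2,5-dichlorophenyl in place of 4-chlorophenyl on an amide-type nitrogen. Going by the values given here, the only measured step, a number 15.7 percentage points lower from compound 2 to compound 3 (beyond the scatter), concerns a nitrophenyl group on a different core and says nothing about a chlorophenyl group, so no measured step bears directly on this change. The step is therefore expected to be a number 0.7 percentage points lower from compound 1 to compound 4 (within the scatter), nothing beyond the scatter. Compound 4 is estimated to give 72% in this assay, with a likely range from 55% to 88%.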

Compound 4, a percentage reported as inhibition, in the whole organism at one dose (the size of the read-out at that dose, not a potency): 50%
For compound 4 the middle estimate is 22 percentage points above the measured one; measured number outside the range, below it.
By their numbers in this assay, from the lowest: compound 4; then compounds 3 and 1 (each within the scatter of the next); then compound 2.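

In this assay the result is a number 22.7 percentage points lower from compound 1 to compound 4 (beyond the scatter) when 2,5-dichlorophenyl replaces 4-chlorophenyl on the amide-type nitrogen. This shows that the chlorophenyl group at this place affects the read-out, which the earlier step, on nitrophenyl groups and a different core, could not show. No measurement at hand explains the drop.

The entering group carries a second chlorine, and the compounds shown cannot separate the effect of that extra atom from the effect of where the chlorines sit. As far as these compounds go, a plain phenyl or a 2-chlorophenyl group on this nitrogen remains open.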